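This account rests on a few compounds, and the source may have more. Where it says the series, first, only, none or still open, it means among the compounds named here.

Three compounds have been measured in a physicochemical assay for lipophilicity; a lower number here means a more polar compound, a higher number a more lipophilic compound:

Compound 1 `COc1ccc(/C=C2\CCC/C(=C\c3ccc([N+](=O)[O-])cc3)C2=O)cc1`: 5.08
Compound 2 `Cc1ccc(/C=C2\CCC/C(=C\c3cccc([N+](=O)[O-])c3)C2=O)cc1`: 5.06
Compound 3 `COc1cc(/C=C2\CCC/C(=C\c3cccc([N+](=O)[O-])c3)C2=O)cc(OC)c1OC`: 5.06

The three readings sit close together. Compound 2 agrees with compound 3 at the digits shown, and the gap from compound 2 to compound 1 also lies within the usual scatter of this kind of measurement, so the three compounds cannot be told apart on these numbers; compound 2 is simply one of the two that print the lowest figure.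

Compound 4 `CN(C)c1ccc(/C=C2\CCC/C(=C\c3cccc([N+](=O)[O-])c3)C2=O)cc1` has not yet been measured in this assay. It differs from compound 2 in one place: dimethylamino in place of methyl on an aromatic carbon. Going by the values given here, no measured pair shows this particular exchange, so there is no step to lean on. The expectation is a modest move downward in this assay, of about the size of the scatter or a little beyond it, expected as a number 0.36 log units lower from compound 2 to compound 4 (beyond the scatter) from compound 2 to compound 4. Compound 4 is accordingly estimated at 4.7, with a likely range from 4.3 to 5.1.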

Compound 4, partition coefficient: 5.06
Beside the measured number, compound 4's estimate is 0.36 log units below it, and the stated range covers the measured number.
By their numbers in this assay, from the lowest: compounds 2, 3, 4 and 1 (each within the scatter of the next).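

In this assay, going by these compounds alone, dimethylamino in place of methyl on this aromatic carbon, the change from 4-methylphenyl to 4-(dimethylamino)phenyl, gives no change at the digits printed from compound 2 to compound 4 (within the scatter), and this is the only step here that isolates a single place in the molecule. The entering group has 3 heavy atoms and 1 hydrogen-bond acceptor, against 1 heavy atom and 0 hydrogen-bond acceptors for methyl, yet this difference leaves the two compounds indistinguishable in this assay. No available evidence accounts for this result.

The compounds shown leave open whether other groups on this aromatic carbon, such as a carboxylic acid, a primary amine or a longer alkyl chain, would also stay within the scatter of compound 2. They also leave open whether the same exchange would read alike on any other position or core.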